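From ethyl to isopropyl on the shared core

This account rests on a few compounds, and the source may have more. Where it says the series, first, only, none or still open, it means among the compounds named here.

In a functional assay on HepG2 cells (Homo sapiens) for antiproliferative activity, read by CCK-8 assay, with a stated time of 72 h (a higher number here means a weaker inhibitor, a lower number a stronger inhibitor), compound 1 (`Nc1ccccc1NC(=O)c1ccc(COc2ccc(Cl)cc2)cc1`) gives > 32000 nM and this is a limit of the assay, not a number. Among the compounds with values here, compound 2 (`CCc1ccc(OCc2ccc(C(=O)Nc3ccccc3N)cc2)cc1`) gives 6960 nM in this assay and so holds the only true number so far.

Compound 3 (`CC(C)c1ccc(OCc2ccc(C(=O)Nc3ccccc3N)cc2)cc1`) differs from compound 2 by methyl in place of hydrogen on a saturated chain carbon bound to an aromatic carbon and a saturated chain carbon, which turns ethyl into isopropyl.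

Within the data shown here, only one measured step bears on this change. It is an at least 4.5-fold lower number from compound 1 to compound 2 (0.66 log units; beyond the scatter) and it swaps ethyl in place of chloro on an aromatic carbon. Its size is open-ended, since it starts from the limit of > 32000 nM in this assay, at which 1 of the 2 values shown sits, in the data. It involves a different exchange, so it gives only a weak guide to direction.

The estimated change is a 1.4-fold lower number from compound 2 to compound 3 (0.14 log units; within the scatter) and it is expected to be small, leaning towards a lower number but not clearly beyond the scatter. For compound 3 the expected value is 5000 nM with an estimated range from 2000 nM to 14000 nM in this assay when measured.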

Compound 3, half-maximal inhibitory concentration: > 32000 nM
Compound 3: only a limit was reported; the forecaster's own chance of this, stated with the estimate: 8%; middle value at least 6.4-fold (0.80 log units) away from the limit.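

In this assay, a single added methyl on the saturated chain carbon bound to an aromatic carbon and a saturated chain carbon, which turns ethyl into isopropyl, gives an at least 4.5-fold higher number from compound 2 to compound 3 (0.66 log units; beyond the scatter). The earlier step had shown only that ethyl reads better than chloro on the shared core; this one shows that the gain is not kept when ethyl becomes isopropyl, so a true number in these compounds depends on the exact group at this place, and compound 2 remains alone in holding one: the limit of > 32000 nM in this assay, at which 2 of the 3 values shown sit. Compound 1 and compound 3 both end at limits, so the step between them cannot be read and chloro and isopropyl cannot be ranked against each other.

As far as these compounds go, how far the real values of compound 1 and compound 3 lie from their limits stays open, and with it the true size of the loss from ethyl to isopropyl. Also open, from the compounds shown here alone, is whether a straight propyl chain or a methoxy group in place of the ethyl would hold, lose or improve on the number of compound 2.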